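Ester to amide and back in mouse hepatocytes

This account rests on a few compounds, and the source may have more. Where it says the series, first, only, none or still open, it means among the compounds named here.

compound 1, `O=C(OC1CCC(CN2CCN(c3cc(=O)c4cc(C(F)(F)F)cc([N+](=O)[O-])c4s3)CC2)CC1)c1ccccc1`: 0.903 h
compound 2, `O=C(NC1CCC(CN2CCN(c3cc(=O)c4cc(C(F)(F)F)cc([N+](=O)[O-])c4s3)CC2)CC1)c1ccccc1`: > 1.55 h

The two measured compounds share one core and differ only at a saturated ring carbon. In an ADME assay on cells (Hepatocyte, Mus musculus) for metabolic stability (a lower number here means that the compound disappears faster, a higher number that the compound lasts longer), compound 1 gives 0.903 h. For compound 2 the read-out > 1.55 h is a limit of the assay and not a number (the limit of > 1.55 h in this assay, at which 1 of the 2 values shown sits). Among the measured compounds shown here, the single measured step, an at least 1.7-fold higher number from compound 1 to compound 2 (0.23 log units; that floor lies within the scatter), accordingly has only a floor, and that floor lies within the scatter, so compound 2 stands simply at the top of the measured range.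

Compound 3, `CC(=O)OC1CCC(CN2CCN(c3cc(=O)c4cc(C(F)(F)F)cc([N+](=O)[O-])c4s3)CC2)CC1`, is not yet measured; it carries acetoxy in place of benzamido on a saturated ring carbon. For the measured compounds named here, the change takes away the benzamido that set compound 2 apart from compound 1 and puts acetoxy in its place, so the step from compound 1 to compound 2, read in reverse, is the only guide. Compound 3 is therefore expected to show an at least 2.5-fold lower number from compound 2 to compound 3 (0.41 log units; beyond the scatter), a move downward from the limit. Compound 3 is estimated at 0.6 h, between 0.25 h and 1.5 h.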

Compound 3, half-life: < 0.15 h
Compound 3 was reported as a limit (the forecaster's own chance of this, stated with the estimate: 10%); middle value at least 4.0-fold (0.60 log units) from the limit.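

The read-out of compound 3 is a limit of this assay and not a number: the limit of < 0.15 h in this assay, at which 1 of the 3 values shown sits.

Even with that limit, this position on the saturated ring carbon now gives steps beyond the scatter, where the earlier step had only a floor within it: an at least 10-fold lower number from compound 2 to compound 3 (1.01 log units; beyond the scatter), and an at least 6.0-fold lower number from compound 1 to compound 3 (0.77 log units; beyond the scatter). The second of these keeps the ester linkage and changes only phenyl to methyl on the carbonyl carbon, so in these compounds the half-life follows the group on the carbonyl carbon and not the linkage alone.

From the compounds shown here alone, the true size of both steps stays unknown, since each has only a floor. Going by these compounds, it also remains open whether an acetamido group at this position would stay with compound 2 or fall toward compound 3, and where a longer chain such as butanoyloxy would lie.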